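The compounds below may be only part of what the source reports. "The series", "measured", "known", "first", "only" and "open" are said of these compounds alone.

Working notes on a short series of thiazolidine carboxamides bearing a saturated chain on the amide nitrogen.

Compound 1, `CCCCCCCCCCNC(=O)[C@@H]1CSC(c2ccc(OC)c(OC)c2)N1`, gives 6300 nM in an ADME assay on cells (Fibroblast, Homo sapiens) for antiproliferative activity, read by sulforhodamine B assay, with a stated time of 48 h; a lower number here means a stronger inhibitor, a higher number a weaker inhibitor. Compound 2, `CCCCCCCCCCCCNC(=O)[C@@H]1CSC(c2ccc(OC)c(OC)c2)N1`, carries the change ethyl in place of hydrogen on a saturated chain carbon, ten or more bonds along the chain from an amide-type nitrogen relative to compound 1, and in this assay compound 2 gives 4500 nM. The step of a 1.4-fold lower number from compound 1 to compound 2 (0.15 log units; within the scatter) is therefore small and does not separate the two compounds.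

Compound 3, `CCCCCCCCCCCCCCNC(=O)[C@@H]1CSC(c2ccccc2)N1`, has a different core from compound 1; the difference between the two cores is not broken down here. In this assay compound 3 gives 2800 nM. Against compound 2 this number lies within the scatter, so no order between compound 2 and compound 3 can be read from these two values; against compound 1 the gap lies beyond the scatter.

Compound 4, `CCCCCCCCCCCCCCCCNC(=O)[C@@H]1CSC(c2ccccc2)N1`, carries the change ethyl in place of hydrogen on a saturated chain carbon, ten or more bonds along the chain from an amide-type nitrogen relative to compound 3. Among the compounds with values here, this is the same change as the one from compound 1 to compound 2, at the same place, so the one measured step is the only guide to its size. Because that step a 1.4-fold lower number from compound 1 to compound 2 (0.15 log units; within the scatter) stayed within the scatter, the step from compound 3 to compound 4 is expected to be of a similar modest size, a 1.3-fold lower number from compound 3 to compound 4 (0.10 log units; within the scatter). For compound 4 in this assay the expected value is 2200 nM, with a likely range from 1000 nM to 4500 nM.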

Compound 4, half-maximal inhibitory concentration: 2200 nM
For compound 4 middle estimate and measured number coincide at the digits printed; low and high end bracket the measured number.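

In this assay, the new step, a 1.3-fold lower number from compound 3 to compound 4 (0.10 log units; within the scatter), is of the same modest size as the earlier one, and the two do not differ across the two cores: the same change on two cores in this assay, a 1.4-fold lower number (0.15 log units; within the scatter) from compound 1 to compound 2 and a 1.3-fold lower number (0.10 log units; within the scatter) from compound 3 to compound 4, 1.1-fold (0.04 log units) apart, within the scatter of two such steps. In these two pairs, ethyl in place of hydrogen on a saturated chain carbon, ten or more bonds along the chain from an amide-type nitrogen, carries from the core of compound 1 to the core of compound 3 with no visible difference in step size. Each step lies within the scatter on its own, however, which leaves open whether the change has any real effect on either core, and two pairs set no rule for other cores in the series.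

The compounds shown leave open how a longer chain on the amide nitrogen, or a saturated chain ending in an amine or a carboxylic acid, would read in this assay. Also open, going by these compounds, is whether the same change keeps its modest size on a core bearing a nitrile or a trifluoromethyl group.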